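The source may hold more compounds than are shown below. What is called first, only, known or untested is meant among the compounds shown, and "the series" means these compounds.

Measured so far in a functional assay on RAW264.7 cells (Mus musculus) for inhibition, read by Griess assay, with stated times of 3 h and 24 h; on this read-out lower numbers stand for stronger inhibition and higher numbers for weaker inhibition:
- compound 1 `C=C1CC[C@H]2[C@@](C)(CCC(=O)N[C@@]2(C)COC(=O)c2ccc([N+](=O)[O-])cc2)[C@@H]1/C=C/C1=CCOC1=O`: 33500 nM
- compound 2 `C=C1CC[C@H]2[C@@](C)(CCC(=O)N[C@@]2(C)COC(=O)[C@@H]2CCCN2)[C@@H]1/C=C/C1=CCOC1=O`: > 50000 nM (a limit)
- compound 3 `C=C1CC[C@H]2[C@@](C)(CC[C@@H](OC(=O)c3cccnc3)[C@@]2(C)NC=O)[C@@H]1/C=C/C1=CCOC1=O`: > 50000 nM (a limit)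

Compound 3 has no number to work from: compound 3 gives > 50000 nM, which is a limit of the assay. Among the compounds with values here, the same ceiling applies to compound 2, and the series so far sits largely there: the limit of > 50000 nM in this assay, at which 2 of the 3 values shown sit.

The change from compound 3 to compound 4 `C=C1CC[C@H]2[C@@](C)(CC[C@@H](OC(=O)[C@H](N)CC(C)C)[C@@]2(C)NC=O)[C@@H]1/C=C/C1=CCOC1=O` is 1-amino-3-methylbutyl in place of pyridin-3-yl on a carbonyl carbon. The group that enters has no ring.

Within the data shown here, only one measured step bears on this change, and only loosely: an at least 1.4-fold higher number from compound 1 to compound 2 (0.17 log units; that floor lies within the scatter). There too, an aromatic ring leaves a carbonyl carbon and a nitrogen-bearing group enters, although the core of compound 1 differs from the core of compound 3. That step is known only as a floor and gives no sign of a gain in this assay. Given an at least 1.4-fold higher number from compound 1 to compound 2 (0.17 log units; that floor lies within the scatter), no step beyond the scatter is expected here, in either direction, and a further limit is the likelier report.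

The estimated step is an at least 1.1-fold lower number from compound 3 to compound 4 (0.04 log units; that floor lies within the scatter).

For compound 4 the expected value is 45000 nM, with an estimated range from 15000 nM to 100000 nM.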

Compound 4, half-maximal inhibitory concentration: > 50000 nM
Compound 4 ended at the assay's limit; the forecaster's own chance of this, stated with the estimate: 55%; middle value at least 1.1-fold (0.04 log units) away from the limit.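

In this assay compound 4 gives > 50000 nM which is a limit of the assay. Within the data shown here, compound 3 also stands at a limit, so no step from compound 3 to compound 4 can be read. These two compounds leave open how 1-amino-3-methylbutyl and pyridin-3-yl on a carbonyl carbon compare in inhibition.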